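Lipophilicity of a thiosemicarbazone pair and one methyl step

A few compounds are considered here, and "the series" means these few. Any claim that something is new, unique, unknown or untested is made for them only; others in the source may bear on it.

Measured so far, in a physicochemical assay for lipophilicity, in phosphate buffer, measured as octanol-water partition, with a stated time of 24 h; on this read-out lower numbers stand for lower lipophilicity and higher numbers for higher lipophilicity:
Compound 1, `Cc1ccc(Oc2ccc(/C=N/NC(=S)Nc3ccccc3)cc2)cc1`, gives 5.39.
Compound 2, `S=C(N/N=C/c1ccc(Oc2ccccc2)cc1)Nc1ccc(Cl)cc1`, gives 5.64.

Compound 2 stands highest of the two numbers, but its nearest neighbour, compound 1, lies within the usual scatter of it, so the two cannot be ordered with confidence. Compound 3, `Cc1ccc(Oc2ccc(/C=N/NC(=S)Nc3ccc(Cl)cc3)cc2)cc1`, has not yet been measured. It differs from compound 2 by methyl in place of hydrogen on an aromatic carbon; cut one bond further out, the change reads phenoxy to 4-methylphenoxy. Going by the values given here, no pair of measured compounds differing in exactly this way is available, so the size of the step in this assay is not anchored by a measured precedent. The author expects a small rise beyond the scatter, a number 0.41 log units higher from compound 2 to compound 3 (beyond the scatter), rather than no change. For compound 3 the estimate is therefore 6.05, with a range from 5.65 to 6.5.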

Compound 3, partition coefficient: 5.97
The estimate for compound 3 lay 0.08 log units above the measured number; measured number inside the range.
By their numbers in this assay, from the lowest: compounds 1 and 2 (each within the scatter of the next); then compound 3.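

In this assay, methyl in place of hydrogen on an aromatic carbon, read as phenoxy to 4-methylphenoxy, gives a number 0.33 log units higher from compound 2 to compound 3 (beyond the scatter) and so supplies the first measured size for this change. Bringing in a chloro group gives a number 0.58 log units higher from compound 1 to compound 3 (beyond the scatter) as the second single change into compound 3, so each change alone moves the number beyond the scatter, something compound 1 and compound 2 could not show, as they lie within the scatter of each other. (Nothing measured here bears on the cause of either step).

Going by these compounds, whether an ethyl group, a methoxy group or a carboxylic acid at the same place would move the number in the same way remains open. Also open, on these data alone, is whether the methyl step keeps its size in a compound without the chloro.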